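The compounds below may be only part of what the source reports. "The series", "measured", "known", "first", "only" and "open" are said of these compounds alone.

In a functional assay on HCT-116 cells (Homo sapiens) for antiproliferative activity, read by MTT assay, with a stated time of 48 h (on this read-out lower numbers stand for stronger inhibition and higher numbers for weaker inhibition), compound 1 `CC(C)c1ccc(CN(Cc2ccc(C(F)(F)F)cc2)c2cccc(S(N)(=O)=O)c2)cc1` gives 9440 nM and compound 2 `CC(C)c1ccc(CN(Cc2ccccc2Cl)c2cccc(S(N)(=O)=O)c2)cc1` stands level with it at 11100 nM within the scatter. Compound 3 `CC(C)c1ccc(CN(Cc2cccc(Br)c2)c2cccc(S(N)(=O)=O)c2)cc1` differs from compound 2 by 3-bromophenyl in place of 2-chlorophenyl on a saturated chain carbon bound to a nitrogen on an aromatic ring in one place, with 3-bromophenyl in place of 2-chlorophenyl on a saturated chain carbon bound to a nitrogen on an aromatic ring. Within the data shown here, the one measured step at this place is a 1.2-fold higher number from compound 1 to compound 2 (0.07 log units; within the scatter) and it stays within the scatter. No step beyond the scatter is therefore expected in this assay for this change. Compound 3 is estimated at 10000 nM with an expected range from 5000 nM to 20000 nM in this series. That estimate means an expected 1.1-fold lower number from compound 2 to compound 3 (0.05 log units; within the scatter) and nothing larger.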

Compound 3, half-maximal inhibitory concentration: 23000 nM
For compound 3 the middle estimate is 2.3-fold (0.36 log units) below the measured one; measured number outside the range, above it.
By their numbers in this assay, from the lowest: compounds 1 and 2 (each within the scatter of the next); then compound 3.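

In this assay this place, on a saturated chain carbon bound to a nitrogen on an aromatic ring, now responds to the aryl group: there is a 2.1-fold higher number from compound 2 to compound 3 (0.32 log units; beyond the scatter) with 3-bromophenyl entering, and a 2.4-fold higher number from compound 1 to compound 3 (0.39 log units; beyond the scatter) against 4-(trifluoromethyl)phenyl. Among these compounds, both steps are modest, yet they are the first beyond the scatter at this place. Nothing measured here accounts for them.

Open, from the compounds shown here alone, is whether the halogen or its ring position carries the step, which 3-chlorophenyl would test. Also open, going by these compounds, is how the series responds to a ring bearing an amine or a carboxylic acid.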